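This account rests on a few compounds, and the source may have more. Where it says the series, first, only, none or still open, it means among the compounds named here.

Working notes on the series. The shared core of compound 1 `O=C1N=C(N2CCC[C@H]2C(=O)Nc2ccc3ncnc(Nc4cccc(Cl)c4)c3c2)S/C1=C/c1ccc(Br)s1` is kept throughout; the compounds differ only in the aryl group on the double-bonded chain carbon bound to a double-bonded ring carbon. In a functional assay on A549 cells (Homo sapiens) for antiproliferative activity, read by MTT assay (a higher number here means a weaker inhibitor, a lower number a stronger inhibitor), compound 1 gives only a limit, > 50000 nM. Compound 2 `O=C1N=C(N2CCC[C@H]2C(=O)Nc2ccc3ncnc(Nc4cccc(Cl)c4)c3c2)S/C1=C/c1cccs1` gives 6100 nM in this assay, and compound 3 `O=C1N=C(N2CCC[C@H]2C(=O)Nc2ccc3ncnc(Nc4cccc(Cl)c4)c3c2)S/C1=C/c1cccnc1Cl` gives 10800 nM. Compound 3 and compound 2 differ only within the scatter, a 1.8-fold higher number from compound 2 to compound 3 (0.25 log units; within the scatter); against compound 1 there is a clear step, an at least 4.6-fold lower number from compound 1 to compound 3 (0.66 log units; beyond the scatter), and likewise an at least 8.1-fold lower number from compound 1 to compound 2 (0.91 log units; beyond the scatter), both of which rest on a limit (the limit of > 50000 nM in this assay, at which 1 of the 3 values shown sits).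

Compound 4 `O=C1N=C(N2CCC[C@H]2C(=O)Nc2ccc3ncnc(Nc4cccc(Cl)c4)c3c2)S/C1=C/c1ccccc1[N+](=O)[O-]` carries the change (2-nitrophenyl in place of 2-chloropyridin-3-yl on a double-bonded chain carbon bound to a double-bonded ring carbon). Going by the values given here, the steps that bear on it are the two aryl swaps at this carbon: an at least 4.6-fold lower number from compound 1 to compound 3 (0.66 log units; beyond the scatter), at least modest, and a 1.8-fold higher number from compound 2 to compound 3 (0.25 log units; within the scatter), within the scatter. One swap moved the number off a limit, the other left it where it was, so an aryl change here can be anything from nothing to a modest step in either direction. Among the compounds with values here, no measured step points in a particular direction for the nitrophenyl group. The expected step of a 1.1-fold lower number from compound 3 to compound 4 (0.03 log units; within the scatter) is therefore none beyond the scatter. Compound 4 is estimated at 10000 nM in this assay, with a range from 3000 nM to 40000 nM.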

Compound 4, half-maximal inhibitory concentration: > 50000 nM
Compound 4 gave a limit, no number; the forecaster's own chance of this, stated with the estimate: 15%; at least 5.0-fold (0.69 log units) between middle value and limit.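

In this assay, 2-nitrophenyl in place of 2-chloropyridin-3-yl gives an at least 4.6-fold higher number from compound 3 to compound 4 (0.66 log units; beyond the scatter), and 2-nitrophenyl in place of thiophen-2-yl gives an at least 8.1-fold higher number from compound 2 to compound 4 (0.91 log units; beyond the scatter), and both steps rest on a limit: the limit of > 50000 nM in this assay, at which 2 of the 4 values shown sit. The earlier compounds shown here had only 5-bromothiophen-2-yl at the limit, so the limit could have been tied to that one group; with compound 4, a six-membered aromatic ring of carbon only reaches it as well, and on this carbon an aryl swap can now be seen to give a step of at least modest size upward from a measured value. The step between compound 1 and compound 4 cannot be read, as both are limits, so the two groups cannot be ranked against each other.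

The compounds shown leave open whether the step belongs to the nitro group or to the phenyl ring itself. A plain phenyl group or a 2-aminophenyl group on the same carbon would separate the two, and would show whether any measured value is possible with a carbon-only ring here.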